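Chloro in Place of Methyl on Two Cores

The compounds below may be only part of what the source reports. "The series", "measured", "known", "first", "only" and "open" are said of these compounds alone.

Compound 1 `CCOC(=O)c1c(-c2c(Cl)c3cc(C)ccc3oc2=O)nn(-c2cccc(C)c2)c1C(=O)OCC` in a functional assay on HeLa cells (Homo sapiens) for cytotoxicity, read by MTT assay, with a stated time of 48 h (on this read-out lower numbers stand for stronger inhibition and higher numbers for weaker inhibition), gives 115000 nM. Compound 2 `CCOC(=O)c1c(-c2c(Cl)c3cc(C)ccc3oc2=O)nn(-c2cccc(Cl)c2)c1C(=O)OCC` in this assay gives 125000 nM. Compound 3 `CCOC(=O)c1c(-c2cc3ccc(OC)cc3oc2=O)nn(-c2cccc(C)c2)c1C(=O)OCC` in this assay gives 35000 nM.

The difference between the core of compound 1 and the core of compound 3 is not broken down here; compound 3 stands lowest of the three, beyond the scatter from both others. Within the first core, the change chloro in place of methyl on an aromatic carbon made a 1.1-fold higher number from compound 1 to compound 2 (0.04 log units; within the scatter). Compound 4 `CCOC(=O)c1c(-c2cc3ccc(OC)cc3oc2=O)nn(-c2cccc(Cl)c2)c1C(=O)OCC` carries the same change on the core of compound 3, (chloro in place of methyl on an aromatic carbon), and has not yet been measured in this assay. The step expected from compound 3 to compound 4 is a 1.1-fold higher number from compound 3 to compound 4 (0.04 log units; within the scatter), because a 1.1-fold higher number from compound 1 to compound 2 (0.04 log units; within the scatter) lay within the scatter. Compound 4 is therefore estimated at 38000 nM, expected between 15000 nM and 95000 nM.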

Compound 4, half-maximal inhibitory concentration: 205000 nM
For compound 4 the middle estimate is 5.4-fold (0.73 log units) below the measured one; measured number above the stated range.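

In this assay, 3-chlorophenyl in place of 3-methylphenyl on the core of compound 3 made a 5.9-fold higher number from compound 3 to compound 4 (0.77 log units; beyond the scatter). The size of the step therefore did not carry over from one core to the other: the same change on two cores in this assay, a 1.1-fold higher number (0.04 log units; within the scatter) from compound 1 to compound 2 and a 5.9-fold higher number (0.77 log units; beyond the scatter) from compound 3 to compound 4, 5.4-fold (0.73 log units) apart, beyond the scatter of two such steps

Among these compounds, this rests on only two pairs, and the two cores differ in more than one place, so it does not show which part of the core matters or how the change would behave on a further core. The compounds shown leave open what an amine or a carboxylic acid would do in place of the chloro or methyl group. They also leave open whether the step on the core of compound 3 would follow the same course with a fluoro or a methoxy group there.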